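A few compounds are considered here, and "the series" means these few. Any claim that something is new, unique, unknown or untested is made for them only; others in the source may bear on it.

Compound 3 `Cc1cccc(N2CCN(C(=O)C(C)N3C(=O)CCC3=O)CC2)c1` is one of three related amides measured in a functional assay on the whole organism (strain Swiss) with Mus musculus as the target, in the maximal electroshock model, with a stated time of 0.5 h, at a dose of 300 mg/kg by the intraperitoneal route; on this read-out higher numbers stand for a stronger effect at the one dose given and lower numbers for a weaker effect. In this assay compound 3 gives 50%. This is level, at the digits reported, with compound 2 `CCC(C(=O)N1CCN(c2cccc(Cl)c2)CC1)N1C(=O)CCC1=O`, which in this assay gives 50%; together they are the lowest of the three numbers. Compound 1 `CC(C(=O)N1CCN(c2cccc(C(F)(F)F)c2)CC1)N1C(=O)CCC1=O` sits above both, and in this assay compound 1 gives 100%. Among the compounds with values here, the only single-site step among the measured compounds is a number 50 percentage points lower from compound 1 to compound 3 (beyond the scatter), a large step that goes beyond the scatter.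

Compound 4 `CC(C(=O)N1CCN(c2cccc(Cl)c2)CC1)N1C(=O)CCC1=O` has not yet been measured. It differs from compound 3 in one place: chloro in place of methyl on an aromatic carbon. In the wider reading, the change is 3-methylphenyl to 3-chlorophenyl. Within the data shown here, no measured pair shows exactly this exchange. The step from compound 1 to compound 3 concerns trifluoromethyl and methyl, not chloro, so it bears on compound 4 only indirectly. Compound 2 carries the same 3-chlorophenyl group as compound 4 and gives a number equal to that of compound 3, which suggests that chloro at this place need not lift the read-out far. The expected step is therefore a number 10 percentage points higher from compound 3 to compound 4 (within the scatter), a modest rise that may not go beyond the scatter. On this basis compound 4 is estimated at 60%, within a range from 30% to 90%.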

Compound 4, a percentage reported as activity, at one dose (the size of the read-out at that dose, not a potency): 100%
Beside the measured number, compound 4's estimate is 40 percentage points below it; the measured number lies above the stated range.
By their numbers in this assay, from the lowest: compounds 2 and 3 (each within the scatter of the next); then compounds 1 and 4 (each within the scatter of the next).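

In this assay, the aromatic carbon that carries the methyl group proves sensitive to what stands there: chloro in place of methyl gives a number 50 percentage points higher from compound 3 to compound 4 (beyond the scatter), while chloro in place of trifluoromethyl gives no change at the digits printed from compound 1 to compound 4 (within the scatter), so chloro and trifluoromethyl cannot be told apart here and methyl is the group that goes with the lower number. The 3-chlorophenyl group does not settle the read-out on its own, since hydrogen in place of methyl on the saturated chain carbon gives a number 50 percentage points higher from compound 2 to compound 4 (beyond the scatter), which shows that this chain position can shift the read-out as strongly as the aromatic position does. Nothing available here accounts for either of these large steps.

Each number comes from one dose and gives the size of the effect at that dose only. On these data alone, how far the read-out would separate the compounds with equal top numbers at lower doses remains open. As far as these compounds go, it is also open whether a methoxy group, a fluoro group or plain hydrogen at this aromatic carbon would go with chloro and trifluoromethyl or with methyl.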